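This account rests on a few compounds, and the source may have more. Where it says the series, first, only, none or still open, it means among the compounds named here.

Of the compounds shown here, two have so far been measured in an assay for inhibition of serine/threonine-protein kinase PAK 4 (Homo sapiens), read by FRET and Z'-LYTE, with a stated time of 60 min, tested at 5 uM, in the presence of a further agent that is not named here; a higher number here means a stronger effect of the compound at the concentration tested, a lower number a weaker effect. Compound 1 `CC(OC(=O)N1CCN(C(=O)c2nc(Nc3cc(C4CC4)[nH]n3)c3cc(Cl)ccc3n2)C[C@H]1C)OC(=O)C(C)(C)C` carries a 1-(((tert-butyl)carbonyl)oxy)ethyl group on an oxygen next to a carbonyl group, and in this assay compound 1 gives 23.6%. For the measured compounds named here, compound 2 `COC(=O)N1CCN(C(=O)c2nc(Nc3cc(C4CC4)[nH]n3)c3cc(Cl)ccc3n2)C[C@H]1C` carries a methyl at that place, and in this assay compound 2 gives 89.6%, the higher of the two numbers; its only neighbour is compound 1, whose number is far lower. Compound 3 `CC(C)OC(=O)N1CCN(C(=O)c2nc(Nc3cc(C4CC4)[nH]n3)c3cc(Cl)ccc3n2)C[C@H]1C` has not yet been measured. It differs from compound 2 in one place: isopropyl in place of methyl on an oxygen next to a carbonyl group. Going by the values given here, only one measured step bears on this change, the one at the same oxygen, which read a number 66 percentage points higher from compound 1 to compound 2 (beyond the scatter) and was large. The isopropyl entering here is much closer to methyl than to the group that left in that step, so a drop for compound 3 in this assay is expected, but a modest one. The step expected in this assay is a number 14.6 percentage points lower from compound 2 to compound 3 (beyond the scatter). Compound 3 is therefore estimated at 75% in this assay, with a range from 45% to 95%.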

Compound 3, a percentage reported as inhibition, at one concentration (the size of the read-out at that concentration, not a potency): 75.8%
For compound 3 the middle estimate is 0.8 percentage points below the measured one; the range from low to high includes it.
By their numbers in this assay, from the lowest: compound 1; then compound 3; then compound 2.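

In this assay the change from methyl to isopropyl on an oxygen next to a carbonyl group reads a number 13.8 percentage points lower from compound 2 to compound 3 (beyond the scatter) and is modest, so this position keeps most of its read-out with a group larger than methyl. The group of compound 1 remains far behind, with a number 52.2 percentage points higher from compound 1 to compound 3 (beyond the scatter) and a large step, which places compound 3 much nearer to compound 2 than to compound 1; as the group on that oxygen grows from methyl through isopropyl to 1-(((tert-butyl)carbonyl)oxy)ethyl the read-out falls, and none of the three compounds goes against this order. No measurement given here offers an explanation for the fall at this oxygen.

The compounds shown leave open whether a straight ethyl or propyl chain, a cyclopropyl ring or a tert-butyl on the same oxygen would fit this order, and whether a group carrying an amine or a carboxylic acid would be accepted there. They also leave open whether the stronger and weaker effects seen here, each read at a single concentration, would hold at other concentrations.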